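Swapping the Side Chain of Compound 1 for Benzylsulfanyl

The source may hold more compounds than are shown below. What is called first, only, known or untested is meant among the compounds shown, and "the series" means these compounds.

Compound 1 `CCCCCNc1nc(N)c2nc(O)n(Cc3ccccc3)c2n1` is the weaker of two measured compounds in a functional assay (spleen, spleen) for activation, with Mus musculus as the target (a higher number here means that more compound is needed for the effect, a lower number that less compound is needed), where compound 1 gives 0.1 uM. The other measured compound, compound 2 `CCCCOc1nc(N)c2[nH]c(=O)n(Cc3ccccc3)c2n1`, carries a butoxy chain and an altered core, and in this assay compound 2 gives 0.001 uM; the distance between these two numbers lies well beyond the usual scatter, so compound 2 clearly needs less compound for the effect.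

The unmeasured compound 3 `Nc1nc(SCc2ccccc2)nc2c1nc(O)n2Cc1ccccc1` differs from compound 1 in one place: benzylsulfanyl in place of pentylamino on an aromatic carbon. Among the compounds with values here, no measured pair shows this exact change, so its size has to be guessed. Because compound 2 gives 0.001 uM while compound 1 gives 0.1 uM, a chain without the amino hydrogen seems compatible with a much lower number, and a downward step a 10-fold lower number from compound 1 to compound 3 (1.00 log units; beyond the scatter) is therefore expected. Compound 3 is estimated at 0.01 uM, within a range from 0.001 uM to 0.1 uM.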

Compound 3, minimum effective concentration: 0.1 uM
The estimate for compound 3 lay 10-fold (1.00 log units) below the measured number; low and high end bracket the measured number.
By their numbers in this assay, from the lowest: compound 2; then compounds 1 and 3 (each within the scatter of the next).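

In this assay, within the data shown here, benzylsulfanyl in place of pentylamino on this aromatic carbon gives no change at the digits printed from compound 1 to compound 3 (within the scatter), a result that no earlier pair could show. The place between two ring nitrogen atoms therefore tolerates, in this pair, a swap that brings in a six-membered aromatic ring of carbon only, puts sulfur in place of nitrogen as the linking atom, and removes the hydrogen-bond donor of pentylamino, all with compound 1 and compound 3 staying within the scatter of each other.

This single step changes the linking atom and the chain together, so it leaves open what each contributes alone, which pentylsulfanyl or benzylamino on the same carbon would help to separate. Nothing presented here offers an explanation for this outcome.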